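Compound 4: Opening the Pyrrolidine Ring

The compounds below may be only part of what the source reports. "The series", "measured", "known", "first", "only" and "open" are said of these compounds alone.

In an ADME assay on Akata cells (Homo sapiens) for cytotoxicity, with a stated time of 7 days (a lower number here means that less compound is tolerated, a higher number that more compound is tolerated), compound 1 (`Nc1nc(OCC(F)(F)F)c2ncn(/C=C3/CC3(CO)CO)c2n1`) gives > 20000 nM, which is a limit and not a number. Compound 2 (`C=CCOc1nc(N)nc2c1ncn2/C=C1/CC1(CO)CO`) gives > 20000 nM, also a limit. Compound 3 (`Nc1nc(N2CCCC2)c2ncn(/C=C3/CC3(CO)CO)c2n1`) gives > 24000 nM, again only a limit, so its standing has no number behind it. Compound 4 (`CCCNc1nc(N)nc2c1ncn2/C=C1/CC1(CO)CO`) carries propylamino in place of pyrrolidin-1-yl on an aromatic carbon. Among the measured compounds shown here, the steps that bear on this change are a step that the two limits leave unreadable from compound 1 to compound 3 and a step that the two limits leave unreadable from compound 2 to compound 3, and neither has a readable size. All three measured compounds sit at limits, so no step beyond the scatter is expected in either direction in this assay. The expected step is a number no higher from compound 3 to compound 4 (the limit leaves the size open). Compound 4 is estimated at 24000 nM. Its expected range for compound 4 runs from 10000 nM to 50000 nM.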

Compound 4, half-maximal cytotoxic concentration: > 24000 nM
Compound 4 ended at the assay's limit (the forecaster's own chance of this, stated with the estimate: 80%); the middle value sits exactly at the limit.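

In this assay, among the compounds shown here, compound 4 gives only a limit, as do compound 1, compound 2 and compound 3, so no step to compound 4 can be read. The compounds shown leave open at what concentration any of them reaches half-maximal cytotoxicity.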